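A few compounds are considered here, and "the series" means these few. Any claim that something is new, unique, unknown or untested is made for them only; others in the source may bear on it.

Measured compounds in a functional assay on DU-145 cells (Homo sapiens) for antiproliferative activity, read by MTT assay, with a stated time of 24 h; on this read-out lower numbers stand for stronger inhibition and higher numbers for weaker inhibition:
compound 1 `COc1cc(-c2cc(/C=C/C(=O)c3ccccc3)nc3cc(-c4ccccc4)nn23)cc(OC)c1OC` gives 34300 nM;
compound 2 `COc1ccc(C(=O)/C=C/c2cc(-c3ccc(OC)c(OC)c3)n3nc(-c4ccccc4)cc3n2)cc1OC` gives 7200 nM.

Of the two compounds measured in this assay, compound 2 stands at the lower number, and compound 1 sits at a higher number, with a gap that lies beyond the usual scatter of this assay; since the two structures differ in several places at once, nothing more than this difference in values can be read from the pair.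

Compound 3 `COc1ccc(C(=O)/C=C/c2cc(-c3cc(OC)c(OC)c(OC)c3)n3nc(-c4ccccc4)cc3n2)cc1OC` follows from compound 2 by one change: methoxy in place of hydrogen on an aromatic carbon. Going by the values given here, no measured pair in this set isolates the same change, so the size of the step is not known from the data. In this assay the step is expected to be a 1.4-fold lower number from compound 2 to compound 3 (0.16 log units; within the scatter), a modest movement, most likely a small shift toward a lower number though not clearly beyond the scatter. For compound 3 the estimate in this assay is 5000 nM, with a range from 1500 nM to 18000 nM.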

Compound 3, half-maximal inhibitory concentration: 29900 nM
Estimate against measurement, compound 3: 6.0-fold (0.78 log units) below, and the stated range ends below it.
By their numbers in this assay, from the lowest: compound 2; then compounds 3 and 1 (each within the scatter of the next).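

In this assay the third methoxy, which turns the 3,4-dimethoxyphenyl group into 3,4,5-trimethoxyphenyl, weakens inhibition: the step is a 4.2-fold higher number from compound 2 to compound 3 (0.62 log units; beyond the scatter) and shows that this aromatic carbon is sensitive to the change, which the first two compounds could not reveal. By contrast, 3,4-dimethoxyphenyl in place of phenyl on the carbonyl carbon gives a 1.1-fold lower number from compound 1 to compound 3 (0.06 log units; within the scatter) with the trimethoxyphenyl group in place, so of the two single changes now seen, only the added methoxy moves the number beyond the scatter. Nothing given here offers an explanation for this loss of inhibition. On these data alone, whether a hydroxyl, a chlorine or an amine on that same carbon would behave like methoxy remains open. So does whether the carbonyl-side swap would be equally silent with the 3,4-dimethoxyphenyl group in place.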